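Ester ring size: cyclobutyl to cyclohexyl in compound 4

The compounds below may be only part of what the source reports. "The series", "measured", "known", "first", "only" and "open" are said of these compounds alone.

Measured in a functional assay on IMR-32 cells for inhibition of Voltage-dependent N-type calcium channel subunit alpha-1B (Homo sapiens), read by calcium flux; a higher number here means a weaker inhibitor, a lower number a stronger inhibitor:
- compound 1 `COc1ccc(COC(=O)[C@H](CC(=O)OC2CCCCCC2)NC(=O)OC(C)(C)C)cc1`: 2600 nM
- compound 2 `COc1ccc(COC(=O)[C@H](COC(=O)C2CCCCC2)NC(=O)OC(C)(C)C)cc1`: 1600 nM
- compound 3 `COc1ccc(COC(=O)[C@H](CC(=O)OC2CCC2)NC(=O)OC(C)(C)C)cc1`: 15000 nM

Compound 3 gives the highest number of the three; the gaps a 5.8-fold higher number from compound 1 to compound 3 (0.76 log units; beyond the scatter) and a 9.4-fold higher number from compound 2 to compound 3 (0.97 log units; beyond the scatter) both lie beyond the scatter, while a 1.6-fold lower number from compound 1 to compound 2 (0.21 log units; within the scatter) does not. Compound 4 `COc1ccc(COC(=O)[C@H](CC(=O)OC2CCCCC2)NC(=O)OC(C)(C)C)cc1` carries a change at the same place: cyclohexyl in place of cyclobutyl on an oxygen next to a carbonyl group. Among the measured compounds shown here, the only step that bears directly on it is a 5.8-fold higher number from compound 1 to compound 3 (0.76 log units; beyond the scatter), the exchange of cycloheptyl for cyclobutyl on this oxygen, which raised the number by a modest margin. Cyclohexyl sits between those two rings in size, so in this assay a drop beyond the scatter is expected for compound 4, roughly a 4.3-fold lower number from compound 3 to compound 4 (0.63 log units; beyond the scatter), likely landing close to compound 1. The estimate for compound 4 is 3500 nM, with a range from 1500 nM to 9000 nM.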

Compound 4, half-maximal inhibitory concentration: 2300 nM
Compound 4: middle estimate off by 1.5-fold (0.18 log units), on the high side, within the range that was stated.
By their numbers in this assay, from the lowest: compounds 2, 4 and 1 (each within the scatter of the next); then compound 3.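

In this assay the cyclobutyl result is now flanked on this oxygen: a 6.5-fold lower number from compound 3 to compound 4 (0.81 log units; beyond the scatter) is a step beyond the scatter, while a 1.1-fold lower number from compound 1 to compound 4 (0.05 log units; within the scatter) leaves cyclohexyl and cycloheptyl indistinguishable, so the high number belongs to cyclobutyl alone among these rings. The ester linkage also reads as interchangeable here, since a 1.4-fold higher number from compound 2 to compound 4 (0.16 log units; within the scatter) stays within the scatter. No measured evidence on the origin of these differences is available.

Cyclopentyl on this oxygen remains open, so the ring size at which the number rises is not located. Also open, going by these compounds, is whether an amine or a carboxylic acid on the cyclohexyl ring would be tolerated.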